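This account rests on a few compounds, and the source may have more. Where it says the series, first, only, none or still open, it means among the compounds named here.

Values in a functional assay on HepG2 cells (Homo sapiens) for antiproliferative activity, read by MTT assay, with a stated time of 48 h; on this read-out higher numbers stand for an effect only at larger amounts of compound and lower numbers for an effect already at smaller amounts:

- compound 1 `CC1=NN(C(=O)CCl)C(c2cc(Cl)ccc2O)C1`: 20300 nM
- compound 2 `CC1=NN(C(=O)CBr)C(c2ccccc2O)C1`: 14400 nM
- compound 3 `CC1=NN(S(=O)(=O)c2ccc([N+](=O)[O-])cc2)C(c2cc(Br)ccc2O)C1`: > 60000 nM

Compound 3 gives > 60000 nM, which is a limit of the assay and not a number. It therefore has no exact place on the scale, and it is the one entry in the set at the limit of > 60000 nM in this assay, at which 1 of the 3 values shown sits. Compound 1 and compound 2 do carry numbers, but each differs from compound 3 in more than one place, so neither gives a direct step.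

Compound 4 `COc1ccc(S(=O)(=O)N2N=C(C)CC2c2cc(Br)ccc2O)cc1` is compound 3 with methoxy in place of nitro on an aromatic carbon, para to a large group (methoxy in place of nitro on an aromatic carbon). Among the measured compounds shown here, no measured pair shows what this exchange does in this assay, so no change beyond the usual scatter is expected, in either direction. The expected move is small, and the estimate for it is an at least 1.0-fold lower number from compound 3 to compound 4 (0.03 log units; that floor lies within the scatter). A reading reported only as a limit would be no surprise. For compound 4 the estimated value is 55000 nM, with an expected range from 20000 nM to 120000 nM.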

Compound 4, half-maximal effective concentration: 38200 nM
Compound 4: middle estimate off by 1.4-fold (0.16 log units), on the high side; the measured number falls inside the stated range.
By their numbers in this assay, from the lowest: compounds 2, 1 and 4 (each within the scatter of the next, the first and the last beyond it). At a limit, above all of these: compound 3.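

With methoxy in place of nitro on an aromatic carbon, para to a large group, this position now carries a real number in this assay: compound 4 gives 38200 nM. The nitro side of the exchange is a limit of the assay and not a number, so the change can be read only as an at least 1.5-fold lower number from compound 3 to compound 4 (0.19 log units; that floor lies within the scatter). The true size of the change stays unknown, since only this floor is available: the limit of > 60000 nM in this assay, at which 1 of the 4 values shown sits.

Going by these compounds, whether the exchange really moves the read-out beyond the scatter remains open, as does what an amine, a carboxylic acid or a longer chain such as butoxy would do at this position. Steps from compound 4 to compound 1 or compound 2 cannot be read, as each differs from it in more than one place.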